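This account rests on a few compounds, and the source may have more. Where it says the series, first, only, none or still open, it means among the compounds named here.

Compound 1 `COc1ccc2c(c1)[n+]([O-])nc(NCOC(C)c1ccccc1)[n+]2[O-]` gives 4140 nM in a functional assay on PC-3 cells (Homo sapiens) for cytotoxicity, read by MTT assay, with a stated time of 72 h; a higher number here means a weaker inhibitor, a lower number a stronger inhibitor; compound 2 `[O-][n+]1nc(NCOCc2ccccc2)[n+]([O-])c2ccccc21` gives 13400 nM; compound 3 `[O-][n+]1nc(NCOCc2ccc(C(F)(F)F)cc2)[n+]([O-])c2ccccc21` gives 7650 nM.

Compound 2 stands highest of the three numbers. Compound 3 is nearest, with a 1.8-fold lower number from compound 2 to compound 3 (0.24 log units; within the scatter), and compound 1 lies furthest, its value sitting beyond the scatter from that of compound 2. Compound 4 `CC(OCNc1n[n+]([O-])c2ccccc2[n+]1[O-])c1ccccc1` differs from compound 2 by methyl in place of hydrogen on a saturated chain carbon bound to an aromatic carbon and an oxygen on a saturated carbon. Within the data shown here, no measured step isolates this change; the only step available, from compound 2 to compound 3, concerned a different group and stayed within the scatter. Compound 1 also bears the methyl but carries a further change on its core, so it guides only loosely. A modest move toward lower numbers is expected for compound 4, estimated at 7500 nM with a range from 3000 nM to 16000 nM. That estimate would mean a 1.8-fold lower number from compound 2 to compound 4 (0.25 log units; within the scatter).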

Compound 4, half-maximal inhibitory concentration: 6080 nM
Beside the measured number, compound 4's estimate is 1.2-fold (0.09 log units) above it, within the range that was stated.
By their numbers in this assay, from the lowest: compounds 1, 4, 3 and 2 (each within the scatter of the next, the first and the last beyond it).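

In this assay, methyl in place of hydrogen on this saturated chain carbon gives a 2.2-fold lower number from compound 2 to compound 4 (0.34 log units; beyond the scatter) and so, unlike the earlier trifluoromethyl step, moves the number modestly beyond the scatter. With that methyl in place, hydrogen in place of methoxy on an aromatic carbon gives a 1.5-fold higher number from compound 1 to compound 4 (0.17 log units; within the scatter) and does not separate the two compounds. No measurement shown here accounts for either step.

Going by these compounds, it remains open whether an ethyl or a hydroxymethyl at this same carbon would give a step of similar size. On these data alone, whether methyl and trifluoromethyl together would add up also remains open.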